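The source may hold more compounds than are shown below. What is called first, only, known or untested is meant among the compounds shown, and "the series" means these compounds.

Compound 1 `Nc1nc(NCc2cccc(Cl)c2)nc(-c2ccccc2CO)n1` gives 4.97 in a functional assay on cells for positive allosteric modulation of G-protein coupled receptor 68 (Homo sapiens), read by a luciferase reporter and cAMP accumulation, with a stated time of 30 min, at pH 6.8 and pH 8.3, in the presence of a further agent that is not named here; a higher number here means a more potent compound, by a factor of ten per unit of this negative logarithm, a lower number a less potent compound. Compound 2 `COc1ccccc1CNc1nc(N)nc(-c2ccccc2CO)n1` gives 3.99 in this assay.

Compound 2 stands lowest of the two measured numbers, and the step from compound 1 to compound 2 was a number 0.98 log units lower from compound 1 to compound 2 (beyond the scatter). Compound 3 `COc1cccc(CNc2nc(N)nc(-c3ccccc3CO)n2)c1` differs from compound 2 by 3-methoxyphenyl in place of 2-methoxyphenyl on a saturated chain carbon bound to a nitrogen on an aromatic ring. For the measured compounds named here, only the step from compound 1 to compound 2 bears on this, and loosely, since it changed both the group and its place. Compound 3 is therefore expected to gain modestly, by a number 0.51 log units higher from compound 2 to compound 3 (beyond the scatter) in this assay. Compound 3 is estimated at 4.5, within 3.9 to 5.1.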

Compound 3, negative logarithm of the antagonist equilibrium constant: 4.11
The estimate for compound 3 lay 0.39 log units above the measured number; low and high end bracket the measured number.
By their numbers in this assay, from the lowest: compounds 2 and 3 (each within the scatter of the next); then compound 1.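

In this assay the place of the methoxy group makes no difference that can be read, with a number 0.12 log units higher from compound 2 to compound 3 (within the scatter) as the step. Compound 1 and compound 3 differ in one place only, so the group can now be read alone: methoxy in place of chloro on an aromatic carbon gives a number 0.86 log units lower from compound 1 to compound 3 (beyond the scatter) as its step. The earlier step changed group and place together, whereas among these three compounds the drop follows the group.

Open, as far as these compounds go, is whether 2-chlorophenyl would keep the number of compound 1, and whether an amine on the aromatic carbon would behave like chloro or like methoxy. No measurement at hand accounts for the gap between chloro and methoxy.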